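Swapping the Aromatic Group for a Furan Ring

A few compounds are considered here, and "the series" means these few. Any claim that something is new, unique, unknown or untested is made for them only; others in the source may bear on it.

Three compounds sharing one core differ only in the aromatic group on a double-bonded chain carbon bound to a double-bonded chain carbon. Compound 1 `COC1=C(C)C(=O)/C(=C(O)/C=C/c2cccc(OC)c2)C(=O)C1(C)C` carries a 3-methoxyphenyl there, compound 2 `COC1=C(C)C(=O)/C(=C(O)/C=C/c2cc(C)cc(C)c2)C(=O)C1(C)C` a 3,5-dimethylphenyl and compound 3 `C=Cc1ccccc1/C=C/C(O)=C1/C(=O)C(C)=C(OC)C(C)(C)C1=O` a 2-vinylphenyl. In a functional assay on HUVEC cells (Homo sapiens) for cytotoxicity (a lower number here means that less compound is needed, a higher number that more compound is needed for the effect), compound 1 gives 1.6 ug/mL, compound 2 gives 2.5 ug/mL and compound 3 gives 1.1 ug/mL. Among these three numbers compound 1 stands second highest; its nearest neighbour is compound 3 and its furthest is compound 2, and both lie within the scatter of it. The steps show the same picture: a 1.6-fold higher number from compound 1 to compound 2 (0.19 log units; within the scatter) and a 1.5-fold lower number from compound 1 to compound 3 (0.16 log units; within the scatter) stay within the scatter, and only a 2.3-fold lower number from compound 2 to compound 3 (0.36 log units; beyond the scatter) reaches beyond it, and modestly so.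

Compound 4 `COC1=C(C)C(=O)/C(=C(O)/C=C/c2ccco2)C(=O)C1(C)C` has not yet been measured in this assay. It differs from compound 1 in one place: furan-2-yl in place of 3-methoxyphenyl on a double-bonded chain carbon bound to a double-bonded chain carbon. The three measured steps all swap the aromatic group at this same place and none moves the number far, so a change of similar small size is expected for compound 4, with no clear direction beyond the scatter. For compound 4 the expected step is a 1.1-fold higher number from compound 1 to compound 4 (0.05 log units; within the scatter). Compound 4 is therefore estimated at 1.8 ug/mL, with a range from 0.8 ug/mL to 4 ug/mL.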

Compound 4, concentration for half-maximal effect: 2.4 ug/mL
Estimate against measurement, compound 4: 1.3-fold (0.12 log units) below, and the stated range covers the measured number.
By their numbers in this assay, from the lowest: compounds 3, 1, 4 and 2 (each within the scatter of the next, the first and the last beyond it).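

In this assay the place on a double-bonded chain carbon bound to a double-bonded chain carbon now carries a five-membered aromatic ring with a hetero atom, furan-2-yl, with 5 heavy atoms against the 8 of 3-methoxyphenyl, and the step, a 1.5-fold higher number from compound 1 to compound 4 (0.18 log units; within the scatter), stays within the scatter, as does a 1.0-fold lower number from compound 2 to compound 4 (0.02 log units; within the scatter) against the 3,5-dimethylphenyl. In these two pairs, then, a smaller ring of another type does not move the number beyond the scatter, so this place is not limited to substituted six-membered carbon rings; the pair that goes against this picture is the one with 2-vinylphenyl, where a 2.2-fold higher number from compound 3 to compound 4 (0.34 log units; beyond the scatter) is beyond the scatter, though only modestly. Nothing shown here explains why the numbers stay so close together.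

All the groups shown at this place are aromatic rings, so it stays open whether an amine, a carboxylic acid or a longer chain of plain carbon would shift the number further. On these data alone, it also stays open whether furan-3-yl or thiophen-2-yl would behave like furan-2-yl.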